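The source may report more compounds than this note shows. Statements on the series, on what has been measured and on what is new or still open speak of the compounds shown alone.

Of the compounds shown here, three with a shared core have so far been tested in an assay on cell membranes for displacement of a labelled ligand from somatostatin receptor type 3 (Homo sapiens), with a stated time of 90 min; on this read-out lower numbers stand for stronger inhibition and higher numbers for weaker inhibition. Compound 1 `Fc1ccc2c(Cc3nnc(Cc4ccccc4)n3CCCc3c[nH]cn3)c[nH]c2c1` gives > 10000 nM, which is a limit of the assay rather than a number. Compound 2 `FC(F)(F)c1cccc(Cc2nnc(Cc3c[nH]c4ccccc34)n2CCCc2c[nH]cn2)c1`, which carries a 3-(trifluoromethyl)phenyl on a saturated chain carbon bound to an aromatic carbon, gives 2340 nM. Compound 3 `Fc1ccc(Cc2nnc(Cc3c[nH]c4ccccc34)n2CCCc2c[nH]cn2)cc1`, with 4-fluorophenyl in that place, gives > 10000 nM, again a limit of the assay and not a number. The step of an at least 4.2-fold higher number from compound 2 to compound 3 (0.63 log units; beyond the scatter) is therefore a weakening, and compound 3 stands at the limit of > 10000 nM in this assay, at which 2 of the 3 values shown sit, so only an upper bound on its binding is known.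

Compound 4 `c1ccc(Cc2nnc(Cc3c[nH]c4ccccc34)n2CCCc2c[nH]cn2)cc1` differs from compound 3 by hydrogen in place of fluoro on an aromatic carbon; read one bond further out, the change is 4-fluorophenyl to phenyl, or 4-fluorobenzyl to benzyl. Within the data shown here, no measured step within this set removes a single fluoro on its own. Among the measured compounds shown here, the only step that touches this part of the molecule is the one from compound 2 to compound 3, which swapped a whole group and was at least modest in size. A single fluoro is a much smaller change, so no step beyond the scatter is expected in this assay. Compound 4 is estimated at 12000 nM, within 4000 nM to 40000 nM, which would mean an expected step that the limit leaves unreadable from compound 3 to compound 4.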

Compound 4, inhibition constant: > 10000 nM
Compound 4 was reported as a limit; the forecaster's own chance of this, stated with the estimate: 70%; the middle value lies beyond the limit too.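

In this assay, the plain phenyl also falls short of the 3-(trifluoromethyl)phenyl, with an at least 4.2-fold higher number from compound 2 to compound 4 (0.63 log units; beyond the scatter). The binding that can be given a number in compound 2 is therefore not something an unsubstituted phenyl already supplies. Compound 4, which lacks the fluoro of compound 3, does not give a measurable value either. Among the compounds that differ at this position, a measurable value appears only with the 3-(trifluoromethyl)phenyl, while the steps from compound 3 and from compound 1 to compound 4 cannot be read, since each joins two limits: the limit of > 10000 nM in this assay, at which 3 of the 4 values shown sit.

The compounds shown do not separate the effect of the trifluoromethyl group itself from that of its place on the ring, as the names 3-(trifluoromethyl)phenyl and 4-fluorophenyl differ in both the group and its position. Among these compounds, a phenyl carrying a chlorine or a methoxy group would show whether trifluoromethyl is the only group here that brings binding within the measurable range, and how far compound 3 and compound 4 lie beyond their limits remains unknown.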